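Notes on the step from compound 2 to compound 3

A few compounds are considered here, and "the series" means these few. Any claim that something is new, unique, unknown or untested is made for them only; others in the source may bear on it.

Measured so far:
compound 1 `COc1ccc(-c2cn(CCCN3C(=O)COc4ccccc43)nn2)cc1` gives 15700 nM
compound 2 `O=C1COc2ccccc2N1CCCn1cc(-c2ccccn2)nn1` gives 5800 nM

Among the measured compounds shown here, in a functional assay on MiaPaCa cells (Homo sapiens) for antiproliferative activity, read by sulforhodamine B assay, with a stated time of 48 h (on this read-out higher numbers stand for weaker inhibition of growth and lower numbers for stronger inhibition of growth), compound 2 stands lowest of the two numbers, the only step being a 2.7-fold lower number from compound 1 to compound 2 (0.43 log units; beyond the scatter), modest but beyond the scatter. Compound 3 `CCCCc1cn(CCCN2C(=O)COc3ccccc32)nn1` differs from compound 2 by butyl in place of pyridin-2-yl on an aromatic carbon. For the measured compounds named here, no measured step covers butyl or loss of a ring; the one known step, a 2.7-fold lower number from compound 1 to compound 2 (0.43 log units; beyond the scatter), shows only that a change of this group shifts the number modestly. A modest rise is expected, estimated as a 2.1-fold higher number from compound 2 to compound 3 (0.32 log units; beyond the scatter). Compound 3 is therefore expected near 12000 nM, within 4000 nM to 40000 nM.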

Compound 3, concentration for 50% growth inhibition: 2500 nM
Compound 3: middle estimate off by 4.8-fold (0.68 log units), on the high side, outside the stated range (below it).
By their numbers in this assay, from the lowest: compound 3; then compound 2; then compound 1.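

In this assay butyl in place of pyridin-2-yl gives a 2.3-fold lower number from compound 2 to compound 3 (0.37 log units; beyond the scatter) and butyl in place of 4-methoxyphenyl gives a 6.3-fold lower number from compound 1 to compound 3 (0.80 log units; beyond the scatter) so an aromatic ring on this aromatic carbon is not needed for growth inhibition in this series. Of the three groups, the one with no ring gives the lowest number, with both steps beyond the scatter. On these data alone, whether a longer chain, a branched chain such as tert-butyl or a butyl chain ending in an amine would lower the number further stays open. Nothing shown here accounts for this order.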